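A few compounds are considered here, and "the series" means these few. Any claim that something is new, unique, unknown or untested is made for them only; others in the source may bear on it.

Compound 1 `ClCc1cccc(Cn2cnc3ncnc(Cl)c32)c1` and compound 2 `ClCc1cccc(Cn2cnc3c(Cl)ncnc32)c1` share the same atoms joined differently; the difference between the two cores is not broken down here. In a functional assay on NCI-H23 cells (Homo sapiens) for cytotoxicity, read by sulforhodamine B assay, with a stated time of 48 h (a higher number here means that more compound is tolerated, a lower number that less compound is tolerated), compound 1 gives 5880 nM and compound 2 gives 8710 nM, two numbers that lie within the usual scatter of each other. Compound 3 `ClCc1cccc(Cn2cnc3c(Cl)nc(Cl)nc32)c1` carries one more chloro group than compound 2 chloro in place of hydrogen on an aromatic carbon and in this assay compound 3 gives 22400 nM, which is a 2.6-fold higher number from compound 2 to compound 3 (0.41 log units; beyond the scatter). Compound 4 `ClCc1cccc(Cn2cnc3nc(Cl)nc(Cl)c32)c1` is related to compound 1 in the same way, by chloro in place of hydrogen on an aromatic carbon. Its value in this assay is not yet known. Because the same change from compound 2 to compound 3 gave a 2.6-fold higher number from compound 2 to compound 3 (0.41 log units; beyond the scatter), a step of similar size is expected from compound 1 to compound 4, a 2.6-fold higher number from compound 1 to compound 4 (0.41 log units; beyond the scatter), and compound 4 is estimated to give about 15000 nM.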

Compound 4, concentration lethal to 50% of the cells: 5370 nM
Beside the measured number, compound 4's estimate is 2.8-fold (0.45 log units) above it; the whole stated range lies above it.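

In this assay, chloro in place of hydrogen on an aromatic carbon gives a 1.1-fold lower number from compound 1 to compound 4 (0.04 log units; within the scatter), so on the core of compound 1 this change leaves the number within the scatter. Set beside the earlier step, the same change does not carry over unchanged from one core to the other: the same change on two cores in this assay, a 2.6-fold higher number (0.41 log units; beyond the scatter) from compound 2 to compound 3 and a 1.1-fold lower number (0.04 log units; within the scatter) from compound 1 to compound 4, 2.8-fold (0.45 log units) apart, beyond the scatter of two such steps. This shows that a step measured on one core cannot simply be assumed on the other in this series, but two pairs give neither a reason for the difference nor a rule for any further core.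

The compounds shown leave open whether an amine or a methoxy group in place of that chloro group would also differ between the two cores. They also leave open how a longer chain on the benzene ring would behave.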